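The compounds below may be only part of what the source reports. "The series", "measured", "known", "first", "only" and "open" are said of these compounds alone.

Among the measured compounds shown here, in a functional assay on A549 cells (Homo sapiens) for antiproliferative activity, read by MTT assay, with a stated time of 48 h (on this read-out lower numbers stand for stronger inhibition and higher numbers for weaker inhibition), compound 2 (`C/C(=C\CC/C(C)=C/CC[C@@H]1[C@@]2(C)CCC(=O)C(C)(C)[C@H]2CC[C@@]1(C)O)CC/C=C(\C)C(=O)OCc1cn(-c2cccc(F)c2)nn1`) gives 124000 nM, the only actual number so far. Compound 1 (`C/C(=C\CC/C(C)=C/CC[C@@H]1[C@@]2(C)CCC(=O)C(C)(C)[C@H]2CC[C@@]1(C)O)CC/C=C(\C)C(=O)OCc1cn(-c2ccccc2[N+](=O)[O-])nn1`) reads > 150000 nM, which is a limit of the assay. Compound 3 (`C/C(=C\CC/C(C)=C/CC[C@@H]1[C@@]2(C)CCC(=O)C(C)(C)[C@H]2CC[C@@]1(C)O)CC/C=C(\C)C(=O)OCc1cn(-c2ccccc2F)nn1`) carries 2-fluorophenyl in place of 3-fluorophenyl on an aromatic nitrogen. For the measured compounds named here, the single measured step bearing on this, an at least 1.2-fold lower number from compound 1 to compound 2 (0.08 log units; that floor lies within the scatter), changes the group at the same place, so it offers no reason to expect a change beyond the scatter in this assay. The estimated step is a 1.0-fold higher number from compound 2 to compound 3 (0.02 log units; within the scatter). Compound 3 is expected at about 130000 nM, with an estimated range of 70000 nM to 220000 nM.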

Compound 3, half-maximal inhibitory concentration: > 150000 nM
Compound 3 ended at the assay's limit; the forecaster's own chance of this, stated with the estimate: 35%; at least 1.1-fold (0.06 log units) between middle value and limit.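

Putting 2-fluorophenyl in place of 3-fluorophenyl on the aromatic nitrogen gives an at least 1.2-fold higher number from compound 2 to compound 3 (0.08 log units; that floor lies within the scatter) in this assay. This shows no effect of moving the fluorine that can be told from the scatter, but it does not rule out a larger step. The step between the two limit values cannot be read, and the comparison stops at a ceiling: the limit of > 150000 nM in this assay, at which 2 of the 3 values shown sit.

From the compounds shown here alone, how far compound 3 actually lies past its limit remains open. So does whether an amine or a carboxylic acid on this phenyl ring would give a clearly lower number.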